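Cytotoxicity on Vero Cells Across a Benzimidazole Thioether Series

The source may report more compounds than this note shows. Statements on the series, on what has been measured and on what is new or still open speak of the compounds shown alone.

The series is assessed in an ADME assay on Vero cells (Chlorocebus sabaeus) for cytotoxicity, read by MTT assay, with a stated time of 24 h; a lower number here means that less compound is tolerated, a higher number that more compound is tolerated. Compound 1 `Cc1ccc(NC(=O)C(C)Sc2nc3ccccc3n2Cc2ccccc2)c(Cl)c1` does not reach a measurable value in this assay, giving only the limit > 75000 nM. Compound 2 `COc1ccc(-n2c(S[C@H](C)C(=O)Nc3ccc(C)cc3Cl)nc3ccccc32)cc1` likewise returns only the limit > 75000 nM in this assay. Compound 3 `COc1ccc(-n2c(SC(C)C(=O)Nc3ccc(Cl)cn3)nc3ccccc32)cc1` has no result reported in this assay ("not determined" (no result reported)), so no number stands for it; what is shown for the rest of the set is the limit of > 75000 nM in this assay, at which 2 of the 3 values shown sit, and nothing here separates any two compounds beyond the usual scatter.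

Compound 4 `COc1ccc(-n2c(SC(C)C(=O)Nc3nc(C)c(Cl)cc3Cl)nc3ccccc32)cc1` is not yet measured. It differs from compound 3 at a single place: 3,5-dichloro-6-methylpyridin-2-yl in place of 5-chloropyridin-2-yl on an amide-type nitrogen. Among the measured compounds shown here, no measured pair in this set shows what such a change does in this assay, so no step can be quoted; the expectation is of no step beyond the scatter, with compound 4 expected to sit where the rest of the set sits. Compound 4 is therefore estimated at 75000 nM, within a range from 30000 nM to 100000 nM, most probably again as a limit rather than a number.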

Compound 4, half-maximal cytotoxic concentration: 7250 nM
Beside the measured number, compound 4's estimate is 10-fold (1.01 log units) above it; measured number below the stated range.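

Among the compounds shown here, compound 3 has no number in this assay, so no step to compound 4, at 7250 nM, can be read. The compounds shown leave open whether the change from 5-chloropyridin-2-yl to 3,5-dichloro-6-methylpyridin-2-yl, or any single part of it, accounts for the value of compound 4.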